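The source may hold more compounds than are shown below. What is called first, only, known or untested is meant among the compounds shown, and "the series" means these compounds.

For the measured compounds named here, compound 1 `O=C(/C=C/c1ccc2c(c1)B(O)OC2)c1ccccc1` is a chalcone-like compound built on a boron-containing bicyclic core, and in a toxicity assay on WI-38 cells (Homo sapiens) for cytotoxicity, read by MTT assay, with a stated time of 48 h (a lower number here means a stronger inhibitor, a higher number a weaker inhibitor), compound 1 gives 19100 nM, the lower of the two numbers measured so far. Its nearest neighbour is compound 2 `O=C(/C=C/c1ccc2c(c1)B(O)OC2)c1ccc(C(F)(F)F)cc1`, which in this assay gives 22600 nM; the step of a 1.2-fold higher number from compound 1 to compound 2 (0.07 log units; within the scatter) is trifluoromethyl in place of hydrogen on an aromatic carbon, and it stays within the usual scatter of repeated measurements.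

Compound 3 `O=C(/C=C/c1ccc2c(c1)B(O)OC2)c1cccc(F)c1` differs from compound 1 by fluoro in place of hydrogen on an aromatic carbon. Going by the values given here, the only measured step that bears on this change is the one from compound 1 to compound 2, a swap of one ring hydrogen for another group on the same phenyl ring, and that step did not move the number beyond the scatter. The expected step of a 1.0-fold lower number from compound 1 to compound 3 (0.00 log units; within the scatter) is therefore estimated to stay within the scatter. Compound 3 is expected to give about 19000 nM in this assay, with a likely range from 9500 nM to 38000 nM.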

Compound 3, half-maximal inhibitory concentration: 26700 nM
Compound 3: the middle estimate sits 1.4-fold (0.15 log units) below what was measured, within the range that was stated.
By their numbers in this assay, from the lowest: compounds 1, 2 and 3 (each within the scatter of the next).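

In this assay, the change from phenyl to 3-fluorophenyl gives a 1.4-fold higher number from compound 1 to compound 3 (0.15 log units; within the scatter) and so adds a second measured ring change to the one already seen, a 1.2-fold higher number from compound 1 to compound 2 (0.07 log units; within the scatter) and neither moves the number beyond the scatter. The new information is specific to this place: a single fluorine on an aromatic carbon, meta to a large group, leaves the cell toxicity reading indistinguishable from that of the unsubstituted phenyl ring of compound 1. Nothing measured here offers an explanation for this result.

As far as these compounds go, whether an amine or a carboxylic acid at this same place would shift the number beyond the scatter remains open. Also open, from the compounds shown here alone, is whether fluoro on another carbon of this ring would behave as it does here.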